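Triazole in Place of Carbamoylphenyl on a Shared Core

The source may hold more compounds than are shown below. What is called first, only, known or untested is meant among the compounds shown, and "the series" means these compounds.

Of the compounds shown here, two built on a shared core have been measured in an assay on CHO cells for displacement of a labelled ligand from adenosine receptor A3 (Homo sapiens), read by scintillation counting, with a stated time of 120 min, tested at 1 uM; on this read-out higher numbers stand for more inhibition at the one concentration tested (going by the name of the read-out) and lower numbers for less inhibition. Compound 1 `N#Cc1c(N)nc(SCc2cccc(C(N)=O)c2)c(C#N)c1-c1ccc(OCC2CC2)cc1` gives 1% in this assay. Compound 2 `CC(C)COc1ccc(-c2c(C#N)c(N)nc(SCC(N)=O)c2C#N)cc1`, which carries a different ether and a different group on the chain at the sulfur, gives 9% in this assay. The two numbers lie within the usual scatter of each other, so no order between compound 1 and compound 2 can be read from them; both show little displacement of the labelled ligand at the concentration tested.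

Compound 3 `N#Cc1c(N)nc(SCc2ncn[nH]2)c(C#N)c1-c1ccc(OCC2CC2)cc1` has not yet been measured. It differs from compound 1 in one place: 1H-1,2,4-triazol-5-yl in place of 3-carbamoylphenyl on a saturated chain carbon bound to a sulfur. For the measured compounds named here, no step between measured compounds tracks this change, so any expectation rests only on the values of compound 1 and compound 2, both of which show little inhibition. Compound 3 is therefore expected to stay near the low end, with an estimated step from compound 1 of a number 4 percentage points higher from compound 1 to compound 3 (within the scatter), which is none beyond the scatter. The estimate for compound 3 in this assay is 5%, within a range of -8% to 22%.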

Compound 3, a percentage reported as inhibition, at one concentration (the size of the read-out at that concentration, not a potency): 1%
Compound 3: middle estimate off by 4 percentage points, on the high side; the measured number falls inside the stated range.
By their numbers in this assay, from the lowest: compounds 1, 3 and 2 (each within the scatter of the next).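

In this assay, for the compounds shown here, the step reads no change at the digits printed from compound 1 to compound 3 (within the scatter), and it is the first step in this set that isolates a single place, the group on a saturated chain carbon bound to a sulfur. It shows that exchanging 3-carbamoylphenyl, with its six-membered aromatic ring of carbon only and 9 heavy atoms, for 1H-1,2,4-triazol-5-yl, with its five-membered aromatic ring and 5 heavy atoms, does not lift the read-out from the low end at this place on the shared core. Nothing measured here bears on why the two groups give this result.

With both compounds at the low end, the step cannot tell whether this place matters for displacement of the labelled ligand or whether the two groups are simply alike in giving little inhibition at the one concentration tested. Still open, as far as these compounds go, is whether a carboxylic acid, an amine or a longer chain in place of either ring would give a read-out beyond the scatter of these numbers.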